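A few compounds are considered here, and "the series" means these few. Any claim that something is new, unique, unknown or untested is made for them only; others in the source may bear on it.

Within the data shown here, in an ADME assay on microsomes from liver (Rattus norvegicus) for metabolic stability, read by LC-MS, tested at 1 mM (on this read-out higher numbers stand for a longer-lived compound and lower numbers for a shorter-lived compound), compound 2 `CS(=O)(=O)c1ccc(-c2c[nH]c3c(=O)n(Cc4cc(F)ccc4C#N)c(N4CCC[C@@H](N)C4)nc23)cc1F` gives 2.78 h, the only exact number so far. Compound 1 `CC(C)S(=O)(=O)c1ccc(-c2c[nH]c3c(=O)n(Cc4cc(F)ccc4C#N)c(N4CCC[C@@H](N)C4)nc23)cc1` reports > 3.33 h, which is a limit of the assay and not a number. Among the measured compounds shown here, the one measured step, an at least 1.1-fold lower number from compound 1 to compound 2 (0.07 log units; that floor lies within the scatter), is also a swap on an aromatic carbon. Compound 3 `CS(=O)(=O)c1ccccc1-c1c[nH]c2c(=O)n(Cc3cc(F)ccc3C#N)c(N3CCC[C@@H](N)C3)nc12` carries 2-(methylsulfonyl)phenyl in place of 3-fluoro-4-(methylsulfonyl)phenyl (2-(methylsulfonyl)phenyl in place of 3-fluoro-4-(methylsulfonyl)phenyl on an aromatic carbon). With that single step as the guide, no shift beyond the scatter is expected. The estimated step is a 1.1-fold lower number from compound 2 to compound 3 (0.05 log units; within the scatter). Compound 3 is expected at 2.5 h, with an estimated range of 1.2 h to 5 h.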

Compound 3, half-life: 3.29 h
Beside the measured number, compound 3's estimate is 1.3-fold (0.12 log units) below it; the range from low to high includes it.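

Within this assay, 2-(methylsulfonyl)phenyl in place of 3-fluoro-4-(methylsulfonyl)phenyl on this aromatic carbon gives a 1.2-fold higher number from compound 2 to compound 3 (0.07 log units; within the scatter), so the half-life does not separate these two groups. The other step, an at least 1.0-fold lower number from compound 1 to compound 3 (0.00 log units; that floor lies within the scatter), offers only a floor, and compound 1 and compound 3 cannot be ordered because compound 1 stands at a limit and not a number: the limit of > 3.33 h in this assay, at which 1 of the 3 values shown sits.

All the compounds shown carry a sulfonyl group on this phenyl ring, so what an amine or a carboxylic acid in its place would do to the half-life stays open.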